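Lengthening the Amine Chain on the Shared Core

This account rests on a few compounds, and the source may have more. Where it says the series, first, only, none or still open, it means among the compounds named here.

Compound 2 `CN(C)CCn1c(N)c(-c2nc3ccccc3[nH]2)c2nc(C#N)c(C#N)nc21` carries a 2-(dimethylamino)ethyl group on the shared core. In a functional assay on A549 cells (Homo sapiens) for antiproliferative activity, read by MTT assay, with a stated time of 48 h (on this read-out lower numbers stand for stronger inhibition and higher numbers for weaker inhibition), compound 2 gives only a limit of the assay, > 50000 nM. Compound 1 `Cn1c(N)c(-c2nc3ccccc3[nH]2)c2nc(C#N)c(C#N)nc21`, which lacks the amine chain, also gives only a limit, > 50000 nM. Compound 3 `CN(C)CCCn1c(N)c(-c2nc3ccccc3[nH]2)c2nc(C#N)c(C#N)nc21`, with a longer chain, gives 10400 nM in this assay. The two limits the limit of > 50000 nM in this assay, at which 2 of the 3 values shown sit, leave the step that the two limits leave unreadable from compound 1 to compound 2 unreadable, but both an at least 4.8-fold lower number from compound 1 to compound 3 (0.68 log units; beyond the scatter) and an at least 4.8-fold lower number from compound 2 to compound 3 (0.68 log units; beyond the scatter) lie beyond the scatter, so among these three compounds a longer chain goes with a lower number. Compound 4 `CCN(CC)CCCCn1c(N)c(-c2nc3ccccc3[nH]2)c2nc(C#N)c(C#N)nc21`, not yet measured, differs from compound 2 in one place: 2-(diethylamino)ethyl in place of dimethylamino on a saturated chain carbon, two bonds along the chain from an aromatic nitrogen. The chain grows further and the amine gains two ethyl groups, a move in the same direction that compound 3 took. A number rather than a limit is therefore expected, with an estimated step of an at least 6.2-fold lower number from compound 2 to compound 4 (0.79 log units; beyond the scatter). For compound 4 the estimate in this assay is 8000 nM, in a range from 2500 nM to 30000 nM.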

Compound 4, half-maximal inhibitory concentration: 5750 nM
Estimate against measurement, compound 4: 1.4-fold (0.14 log units) above; measured number inside the range.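

In this assay, the 4-(diethylamino)butyl group gives a measured number, with an at least 8.6-fold lower number from compound 2 to compound 4 (0.93 log units; beyond the scatter) and an at least 8.6-fold lower number from compound 1 to compound 4 (0.93 log units; beyond the scatter), and both of these steps start from a limit of the assay. What is new is the step from the previous best-placed compound: a 1.8-fold lower number from compound 3 to compound 4 (0.26 log units; within the scatter), so compound 3 and compound 4 cannot be told apart here. Among these compounds, the trend of a longer chain going with a lower number, seen up to compound 3, therefore finds no readable continuation in compound 4, the one compound that goes against it.

Compound 4 differs from compound 3 in both chain length and the groups on the amine, so the two changes cannot be separated. A diethylamino group on the shorter chain of compound 3, a dimethylamino group on the longer chain of compound 4, or a ring amine such as morpholine would remain to be compared.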